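Working notes on a three-compound series and one chain change

A few compounds are considered here, and "the series" means these few. Any claim that something is new, unique, unknown or untested is made for them only; others in the source may bear on it.

Three compounds have numbers in a functional assay on MIA PaCa-2 cells (Homo sapiens) for inhibition, read by MTT assay, with a stated time of 72 h, tested at 30 uM (on this read-out lower numbers stand for less inhibition of growth and higher numbers for more inhibition of growth at the one concentration tested), so far. Compound 1 `C=CCc1cc(O)c(O)c(CN2CCC(CO)CC2)c1` gives 34.1% in this assay. Compound 2 `C=CCc1ccc(OCc2cn(-c3cc(OC)c(OC)c(OC)c3)nn2)c(O)c1` gives 41.1% in this assay. Compound 3 `C=CCc1ccc(OCc2cn(-c3ccc(Br)cc3)nn2)c(O)c1` gives 43.3% in this assay. Within the data shown here, on these three numbers compound 1 stands lowest, yet its nearest neighbour, compound 2, lies within the scatter of it, and so does its furthest neighbour, compound 3; the three values therefore cannot be placed in an order that means anything, and no step between any pair of them is known.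

The next compound, compound 4 `C=CCc1cc(O)c(O)c(CN2CCC(C)CC2)c1`, differs from compound 1 in one place: hydrogen in place of hydroxy on a saturated chain carbon bound to a saturated ring carbon. No pair with the same change has been measured, so there is no shown step to lean on. The change removes a hydroxy and leaves a hydrogen on a saturated chain carbon bound to a saturated ring carbon; nothing else in the shared core moves. Given how close all three measured numbers already sit, the expectation for compound 4 is a step of a number 0.1 percentage points lower from compound 1 to compound 4 (within the scatter) from compound 1, that is, nothing beyond the scatter in either direction. Compound 4 is thus estimated at 34%, with a range from 22% to 46%.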

Compound 4, percent growth inhibition at one concentration: 91.5%
Beside the measured number, compound 4's estimate is 57.5 percentage points below it; the measured number lies above the stated range.
By their numbers in this assay, from the lowest: compounds 1, 2 and 3 (each within the scatter of the next); then compound 4.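

In this assay, among these compounds, the change from hydroxymethyl to methyl comes with a number 57.4 percentage points higher from compound 1 to compound 4 (beyond the scatter), the first step that stands clear of the scatter. This shows that the place, a saturated chain carbon bound to a saturated ring carbon, is not indifferent to what it carries: one hydroxy giving way to hydrogen, with the rest of the shared core untouched, is enough to move the read-out from the low level of compound 1 to the high level of compound 4. Nothing measured on these compounds speaks to what lies behind a step of this size.

Going by these compounds, the finding rests on a single pair, so it stays open whether the same change would give a comparable step on another core, and whether the step would hold at other concentrations, given that the read-out comes from one concentration only. Also open, on these data alone, is where a longer chain such as ethyl, an aminomethyl group or a carboxylic acid at this place would fall, whether near compound 1, near compound 4 or somewhere in the wide gap that separates them.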